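The source may hold more compounds than are shown below. What is called first, only, known or untested is meant among the compounds shown, and "the series" means these compounds.

Within the data shown here, compound 2 `O=S(=O)(C1=C(Cl)NC2SC=CN12)c1cn(C2CCCNC2)c2ncccc12` is the more potent of the two compounds measured so far. In a functional assay on HeLa cells for agonist activity at 5-hydroxytryptamine receptor 6 (Homo sapiens), read by cAMP accumulation and immunoassay (a higher number here means that more compound is needed for the effect, a lower number that less compound is needed), compound 2 gives 66 nM, the lowest number of the pair, whereas compound 1 `CN1CCCC(n2cc(S(=O)(=O)c3cccc(F)c3)c3cccnc32)C1` gives 306 nM in this assay, a gap well beyond the usual scatter. Compound 1 also differs from compound 2 in the group attached to the sulfone, so the two values alone cannot say what the amine substitution contributes.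

Compound 3 `CN1CCCC(n2cc(S(=O)(=O)C3=C(Cl)NC4SC=CN34)c3cccnc32)C1` keeps the whole of compound 2 except for one change: methyl in place of hydrogen on an amine nitrogen in a ring. Among the measured compounds shown here, no pair of measured compounds shows this single change on its own, so there is no direct precedent. The expected step from compound 2 to compound 3 is a 1.7-fold higher number from compound 2 to compound 3 (0.22 log units; within the scatter), a modest rise that may not exceed the scatter. On that basis compound 3 is expected to give about 110 nM in this assay, somewhere between 35 nM and 350 nM.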

Compound 3, half-maximal effective concentration: 25 nM
Beside the measured number, compound 3's estimate is 4.4-fold (0.64 log units) above it; the whole stated range lies above it.
By their numbers in this assay, from the lowest: compound 3; then compound 2; then compound 1.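

In this assay, methyl in place of hydrogen on the ring amine nitrogen gives a 2.6-fold lower number from compound 2 to compound 3 (0.42 log units; beyond the scatter) and so shows that this single added carbon changes the number on its own, in the direction of less compound being needed. Compound 3 also isolates the group on the sulfonyl sulfur, since the 1-methylpiperidin-3-yl group stays fixed: replacing the fluorine-bearing aromatic ring of compound 1 with the group of two five-membered non-aromatic rings gives a 12-fold lower number from compound 1 to compound 3 (1.09 log units; beyond the scatter) and is the larger of the two changes. No supporting measurement explains either step.

As far as these compounds go, only hydrogen and methyl are seen on this nitrogen, so it remains open whether an ethyl group or a longer chain would lower the number further. From the compounds shown here alone, it is also open whether the methyl step would hold with the aromatic ring of compound 1 on the sulfonyl sulfur.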